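A few compounds are considered here, and "the series" means these few. Any claim that something is new, unique, unknown or untested is made for them only; others in the source may bear on it.

Measured compounds:
- Compound 1, `CC(C)(C)OC(=O)N1CCC2(CCC(CCCOc3ccc(S(C)(=O)=O)cc3)CC2)CC1`: 2590 nM
- Compound 2, `CC(C)OC(=O)N1CCC2(CC1)CC(CCCOc1ccc(C(=O)N(C)C3CC3)c(F)c1)C2`: 67 nM

In a functional assay on cells for agonist activity at Glucose-dependent insulinotropic receptor (Homo sapiens), read by HTRF and cAMP accumulation, with a stated time of 30 min (on this read-out lower numbers stand for an effect already at smaller amounts and higher numbers for an effect only at larger amounts of compound), compound 2 gives 67 nM, the lower of the two numbers recorded. Compound 1 gives 2590 nM in this assay, a number that stands far above that of compound 2, well beyond the usual scatter. The two compounds differ in several places at once, so their gap says nothing about any single change.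

Compound 3, `CC(C)OC(=O)N1CCC2(CC1)CC(CCCOc1ccc(C(=O)N3CC(O)C3)c(F)c1)C2`, differs from compound 2 in one place only: 3-hydroxyazetidin-1-yl in place of cyclopropyl(methyl)amino on a carbonyl carbon. Going by the values given here, no measured pair shows this particular exchange, so there is no step in hand to lean on. With the amide carbonyl kept in place and the group on its nitrogen exchanged for one of the same size, the expectation is a step of modest size, more likely toward a somewhat higher number than toward a lower one, and possibly none beyond the scatter at all. On that basis compound 3 is expected to give 150 nM in this assay, within a range from 40 nM to 600 nM, which is the estimated step of a 2.2-fold higher number from compound 2 to compound 3 (0.35 log units; beyond the scatter).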

Compound 3, half-maximal effective concentration: 40 nM
Compound 3: the middle estimate sits 3.8-fold (0.57 log units) above what was measured; the measured number falls inside the stated range.
By their numbers in this assay, from the lowest: compounds 3 and 2 (each within the scatter of the next); then compound 1.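

In this assay the exchange of cyclopropyl(methyl)amino for 3-hydroxyazetidin-1-yl on a carbonyl carbon gives a 1.7-fold lower number from compound 2 to compound 3 (0.22 log units; within the scatter) and so leaves the two compounds indistinguishable on this read-out. Going by these compounds alone, the entering group has the same count of heavy atoms as the one it replaces, but it brings an oxygen, a hydrogen-bond donor and a hydrogen-bond acceptor, and a four-membered ring with a hetero atom takes the place of a three-membered ring of carbon only, so this one place tolerates these differences in the pair at hand, something the earlier compounds, which differ in several places at once, could not show. Nothing measured here says what lies behind this outcome.

The pair cannot separate the ring from the hydroxyl, a question that plain azetidin-1-yl on the same carbonyl carbon would address. From the compounds shown here alone, how far this tolerance extends also stays open, for instance to a group carrying a carboxylic acid or an amine, or to a longer chain, at this same place.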